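This account rests on a few compounds, and the source may have more. Where it says the series, first, only, none or still open, it means among the compounds named here.

Measured so far in an in vitro assay on cells for binding affinity to myelin-associated glycoprotein (Mus musculus), read by surface plasmon resonance; on this read-out lower numbers stand for tighter binding and higher numbers for weaker binding:

Compound 1 `CC(=O)N[C@H]1[C@H]([C@@H](O)[C@H](O)CNC(=O)c2ccc(Cl)cc2)O[C@@](OCc2ccc(Cl)cc2)(C(=O)O)C[C@@H]1O` — compound 1 gives 15000 nM.
Compound 2 `CC(=O)N[C@H]1[C@H]([C@@H](O)[C@H](O)CNC(=O)c2ccc(Cl)cc2)O[C@@](OCc2ccc(F)cc2)(C(=O)O)C[C@@H]1O` — compound 2 gives 13000 nM.
Compound 3 `CC(=O)N[C@H]1[C@H]([C@@H](O)[C@H](O)CNC(=O)c2ccc(Cl)cc2)O[C@@](OCc2c(F)c(F)c(F)c(F)c2F)(C(=O)O)C[C@@H]1O` — compound 3 gives 6100 nM.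

Compound 3 has the lowest number of the three, so on this read-out it binds most tightly; its nearest neighbour is compound 2, and the gap to it, like the gap to compound 1, is beyond the usual scatter.

The next step leads to compound 4 `CC(=O)N[C@H]1[C@H]([C@@H](O)[C@H](O)CNC(=O)c2ccc(Cl)cc2)O[C@@](OCc2ccc3ccccc3c2)(C(=O)O)C[C@@H]1O`. The change is naphthalen-2-yl in place of 2,3,4,5,6-pentafluorophenyl on a saturated chain carbon bound to an oxygen on a saturated carbon. The three compounds share everything else: the same core and the same chlorinated benzamide on the side chain, so only the aromatic group on that chain carbon changes.

Among the measured compounds shown here, two measured steps touch this same position. Swapping the 4-chlorophenyl of compound 1 for the pentafluorophenyl gave a 2.5-fold lower number from compound 1 to compound 3 (0.39 log units; beyond the scatter), and the same swap from compound 2 gave a 2.1-fold lower number from compound 2 to compound 3 (0.33 log units; beyond the scatter). Both are modest, and both point to tighter binding when the pentafluorophenyl replaces a singly substituted phenyl. For the measured compounds named here, no measured compound carries a fused two-ring aromatic group, so a step from compound 3 to compound 4 of a 1.2-fold lower number from compound 3 to compound 4 (0.09 log units; within the scatter) is expected, that is, little change beyond the scatter. Compound 4 is therefore estimated at 5000 nM, within a range from 1500 nM to 15000 nM.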

Compound 4, dissociation constant in the myelin-associated glycoprotein assay: 11600 nM
Compound 4: middle estimate off by 2.3-fold (0.37 log units), on the low side, within the range that was stated.
By their numbers in the myelin-associated glycoprotein assay, from the lowest: compounds 3, 4, 2 and 1 (each within the scatter of the next, the first and the last beyond it).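

Among the compounds shown here, in the myelin-associated glycoprotein assay the naphthalen-2-yl group, with its 2 six-membered aromatic rings of carbon only, gives a 1.9-fold higher number from compound 3 to compound 4 (0.28 log units; within the scatter) along with a 1.1-fold lower number from compound 2 to compound 4 (0.05 log units; within the scatter) and a 1.3-fold lower number from compound 1 to compound 4 (0.11 log units; within the scatter) and all three steps lie within the scatter, so this position takes a fused two-ring aromatic group with no binding step that can be told from noise. The earlier compounds had shown a modest gap separating compound 3 from compounds 1 and 2, yet compound 4 lies within the scatter of all three, so it cannot be placed on either side of that gap. In a physicochemical assay for lipophilicity, using the shake flask method, measured as octanol-water partition, at pH 7.4 (a higher number here means a more lipophilic compound, a lower number a more polar compound), compound 3 gives -0.11 and compound 4 gives 0.58, so the same change does register, and a clear shift in this read-out came here with no binding step beyond the scatter: the measured distribution coefficient of compound 3, -0.11, and of compound 4, 0.58, a number 0.69 log units higher (beyond the scatter).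

Still open, on these data alone, is whether a longer chain carrying the naphthalen-2-yl group, or an amine on that group, would move binding beyond the scatter. All the compounds shown also carry the same chlorinated benzamide on the side chain, so whether these steps hold with a carboxylic acid on that benzamide remains unknown.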